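The source may hold more compounds than are shown below. What is called first, only, known or untested is meant among the compounds shown, and "the series" means these compounds.

Three compounds have so far been measured in an ADME assay on HT-29 cells (Homo sapiens) for cytotoxicity, read by MTT assay, with a stated time of 72 h; on this read-out lower numbers stand for stronger inhibition and higher numbers for weaker inhibition:

compound 1 `C=CC(=O)Nc1cc(Nc2ncc3ncn(-c4ccc(C(C)C)cc4)c3n2)c(OC)cc1N(C)CCN(C)C` — 15300 nM
compound 2 `C=CC(=O)Nc1cc(Nc2ncc3ncn(-c4ccc(F)cc4)c3n2)c(OC)cc1N(C)CCN(C)C` — 12000 nM
compound 3 `C=CC(=O)Nc1cc(Nc2ncc3ncn(-c4ccc(I)cc4)c3n2)c(OC)cc1N(C)CCN(C)C` — 9520 nM

Compound 3 holds the lowest of the three numbers, but none of the gaps reaches beyond the scatter: a 1.3-fold lower number from compound 2 to compound 3 (0.10 log units; within the scatter) and a 1.6-fold lower number from compound 1 to compound 3 (0.21 log units; within the scatter). Compound 4 `C=CC(=O)Nc1cc(Nc2ncc3ncn(-c4ccc(F)c(Br)c4)c3n2)c(OC)cc1N(C)CCN(C)C` differs from compound 3 by 3-bromo-4-fluorophenyl in place of 4-iodophenyl on an aromatic nitrogen. Among the measured compounds shown here, the steps that bear on this change are the earlier exchanges on the same aromatic ring: a 1.3-fold lower number from compound 1 to compound 2 (0.11 log units; within the scatter), a 1.6-fold lower number from compound 1 to compound 3 (0.21 log units; within the scatter) and a 1.3-fold lower number from compound 2 to compound 3 (0.10 log units; within the scatter), all within the scatter. No step beyond the scatter is therefore expected in this assay. Compound 4 is expected to give about 10000 nM, in the range 5000 nM to 20000 nM, which would mean an expected step of a 1.1-fold higher number from compound 3 to compound 4 (0.02 log units; within the scatter).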

Compound 4, half-maximal inhibitory concentration: 3640 nM
Compound 4: the middle estimate sits 2.7-fold (0.44 log units) above what was measured; the whole stated range lies above it.
By their numbers in this assay, from the lowest: compound 4; then compounds 3, 2 and 1 (each within the scatter of the next).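

At the aromatic nitrogen, a change on the phenyl ring now moves the number beyond the scatter in this assay: 3-bromo-4-fluorophenyl in place of 4-iodophenyl gives a 2.6-fold lower number from compound 3 to compound 4 (0.42 log units; beyond the scatter) and in place of 4-isopropylphenyl gives a 4.2-fold lower number from compound 1 to compound 4 (0.62 log units; beyond the scatter). Adding only bromo in place of hydrogen to the fluorophenyl ring gives a 3.3-fold lower number from compound 2 to compound 4 (0.52 log units; beyond the scatter), so this one added atom produces a modest step, whereas every earlier exchange on this ring stayed within the scatter. Nothing available explains this step.

As far as these compounds go, whether chloro or methoxy in place of the bromo would give a similar step remains open. So does the effect of the bromo without the fluoro, or of an amine on the same ring.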